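A few compounds are considered here, and "the series" means these few. Any claim that something is new, unique, unknown or untested is made for them only; others in the source may bear on it.

In a functional assay (mast cells) with Rattus norvegicus as the target (a higher number here means a weaker inhibitor, a lower number a stronger inhibitor), compound 1 `Oc1nnc(-c2nc3ccccc3o2)o1` gives 1200 nM. Compound 3 `CCOC(=O)c1ccc2oc(-c3nnc(O)o3)nc2c1`, at 1000 nM, cannot be told apart from it, whereas compound 2 `Cc1ccc2nc(-c3nnc(O)o3)oc2c1`, at 5000 nM, is clearly weaker. Compound 1 therefore stands with compound 3, apart from compound 2.

Compound 4 `Cc1cccc2oc(-c3nnc(O)o3)nc12` differs from compound 1 by one change, methyl in place of hydrogen on an aromatic carbon. The methyl sits on a six-membered aromatic ring of carbon only, ortho to a fused ring and meta to a fused ring.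

The nearest guide is a 4.2-fold higher number from compound 1 to compound 2 (0.62 log units; beyond the scatter), the same exchange on another aromatic carbon. The exchange to ethoxycarbonyl gave a 1.2-fold lower number from compound 1 to compound 3 (0.08 log units; within the scatter), but that is a different group. No methyl at the new carbon has been measured, so the guide is imperfect. A modest rise is expected, an estimated 2.0-fold higher number from compound 1 to compound 4 (0.30 log units; within the scatter), somewhat smaller than the measured methyl step. Compound 4 is expected near 2400 nM, within an estimated range of 800 nM to 7000 nM.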

Compound 4, half-maximal inhibitory concentration: 1000 nM
Beside the measured number, compound 4's estimate is 2.4-fold (0.38 log units) above it; low and high end bracket the measured number.
By their numbers in this assay, from the lowest: compounds 3, 4 and 1 (each within the scatter of the next); then compound 2.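

In this assay, methyl in place of hydrogen on this carbon, ortho to a fused ring and meta to a fused ring, produces no change beyond the scatter (a 1.2-fold lower number from compound 1 to compound 4 (0.08 log units; within the scatter)). The same exchange on another aromatic carbon gave a step beyond the scatter (a 4.2-fold higher number from compound 1 to compound 2 (0.62 log units; beyond the scatter)), so among these compounds the outcome of adding a methyl depends on which carbon carries it, and this carbon accepts the group without a measurable loss. Nothing available here accounts for the difference between the two carbons.

The compounds shown leave open whether a methoxy group, an amine or a carboxylic acid on this same carbon would also stay within the scatter of compound 1. They also leave open whether the ethoxycarbonyl group of compound 3 would give a similar result if moved to this carbon.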